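This account rests on a few compounds, and the source may have more. Where it says the series, first, only, none or still open, it means among the compounds named here.

Compound 3, with the structure `COc1ccc(N2CCN(Cc3csc(N)c3C(=O)c3ccc(Cl)cc3)CC2)cc1`, is one of three compounds examined in a functional assay on CHO cells with adenosine receptor A1 (Homo sapiens) as the target, read by cAMP accumulation and immunoassay, with a stated time of 6 min, tested at 0.01 uM (a lower number here means a stronger effect, a higher number a weaker effect of the compound at the concentration tested), where compound 3 gives -1.2%. Its nearest neighbour on these numbers is compound 1, `Nc1scc(CN2CCN(c3ccc(F)cc3Cl)CC2)c1C(=O)c1ccc(Cl)cc1`, which in this assay reads 6.1%; the step of a number 7.3 percentage points lower from compound 1 to compound 3 (within the scatter) lies within the scatter, as does a number 8 percentage points higher from compound 2 to compound 3 (within the scatter) to compound 2, `Nc1scc(CN2CCN(c3ccc(Cl)cc3F)CC2)c1C(=O)c1ccc(Cl)cc1`, which gives -9.2%. Compound 3 thus stands second highest of the three, separated from neither neighbour by more than the scatter. Going by the values given here, the only step beyond the scatter is a number 15.3 percentage points lower from compound 1 to compound 2 (beyond the scatter).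

Compound 4, `Nc1scc(CN2CCN(c3ccc([N+](=O)[O-])cc3)CC2)c1C(=O)c1ccc(Cl)cc1`, has not yet been measured. It differs from compound 3 by nitro in place of methoxy on an aromatic carbon. The measured steps that bear on this are the two exchanges of the aryl group on the amine nitrogen in the ring, a number 7.3 percentage points lower from compound 1 to compound 3 (within the scatter) and a number 8 percentage points higher from compound 2 to compound 3 (within the scatter), both within the scatter, while a number 15.3 percentage points lower from compound 1 to compound 2 (beyond the scatter) shows that a rearrangement of halogens on that aryl can shift the read-out modestly. Among the compounds with values here, no step here exchanges a methoxy for a nitro, so the expectation rests on the general insensitivity of the read-out to the aryl substituent. Compound 4 is therefore expected to show a number 0.8 percentage points lower from compound 3 to compound 4 (within the scatter), a step not beyond the scatter. The estimate for compound 4 is -2%, with a range from -14% to 10%.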

Compound 4, a percentage reported as activity, at one concentration (the size of the read-out at that concentration, not a potency): -12%
The estimate for compound 4 lay 10 percentage points above the measured number; low and high end bracket the measured number.
By their numbers in this assay, from the lowest: compounds 4, 2, 3 and 1 (each within the scatter of the next, the first and the last beyond it).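

Among the earlier compounds, the steps involving compound 3 stayed within the scatter in this assay, but the exchange of methoxy for nitro on the aromatic carbon para to a large group gives a number 10.8 percentage points lower from compound 3 to compound 4 (beyond the scatter). This shows that changing this one substituent can move the read-out beyond the scatter, although only modestly. The 4-nitrophenyl group also stands apart from the 2-chloro-4-fluorophenyl group, with a number 18.1 percentage points lower from compound 1 to compound 4 (beyond the scatter), but a number 2.8 percentage points lower from compound 2 to compound 4 (within the scatter) does not separate it from the 4-chloro-2-fluorophenyl group, so two differently substituted aryl groups give read-outs within the scatter of each other, and no available measurement accounts for the shift.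

On these data alone, whether this shift is particular to nitro, or would also appear with an amine, a nitrile or a carboxylic acid at the same place, remains open, as does the read-out of a plain phenyl group with no substituent. Because each compound is represented by a read-out at one concentration, the compounds shown also leave open whether these steps would hold at other concentrations.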